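Replacing a bicyclic amide with an oxolane ring

This account rests on a few compounds, and the source may have more. Where it says the series, first, only, none or still open, it means among the compounds named here.

Of the compounds shown here, three built on the shared core have been measured in an assay on CHO cells for displacement of a labelled ligand from histamine receptor H3 (Macaca mulatta); on this read-out higher numbers stand for weaker inhibition and lower numbers for stronger inhibition. Compound 1 `Cc1cc(N2CCC(N3CCCC3C)C2)ccc1NC(=O)C1CCOCC1` gives 6.8 nM. Compound 2 `CC1CCCN1C1CCN(c2ccc(NC(=O)C3C(C)(C)C3(C)C)cc2)C1` gives 144 nM, and compound 3 `Cc1cc(NC(=O)C2CC3CCC2C3)ccc1N1CCC(N2CCCC2C)C1` gives 130 nM, the second highest of the three numbers; its gap to compound 2 lies within the scatter, while compound 1 sits well below it, beyond the scatter. Compound 4 `Cc1cc(NC(=O)C2CCCO2)ccc1N1CCC(N2CCCC2C)C1` differs from compound 3 in one place: a group of 5 heavy atoms (4 carbon, 1 oxygen; one five-membered non-aromatic ring with 1 hetero atom) in place of a group of 7 heavy atoms (7 carbon; 2 five-membered non-aromatic rings of carbon only), on a carbonyl carbon. For the measured compounds named here, no measured pair shows this change, so its effect is unknown. Since compound 1 with its smaller, oxygen-containing amide ring gives 6.8 nM, compound 4 is expected to move toward lower numbers, with an estimated step of a 3.7-fold lower number from compound 3 to compound 4 (0.57 log units; beyond the scatter). For compound 4 an inhibition constant of 35 nM is estimated, between 9 nM and 130 nM.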

Compound 4, inhibition constant: 17 nM
Compound 4: middle estimate off by 2.1-fold (0.31 log units), on the high side; low and high end bracket the measured number.
By their numbers in this assay, from the lowest: compound 1; then compound 4; then compounds 3 and 2 (each within the scatter of the next).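

In this assay, for the compounds shown here, the group on the carbonyl carbon gives the first comparison of compounds differing in one place, with oxolan-2-yl in place of the two-ring all-carbon group: a 7.6-fold lower number from compound 3 to compound 4 (0.88 log units; beyond the scatter). Going by these compounds alone, this shows that the position responds to the exchange, but the exchange alters the heavy-atom count, the ring system and the hydrogen-bond acceptor count at once, and the single step cannot tell these apart. Nothing at hand explains the step.

Whether the oxygen or the reduced group size accounts for the step remains open. A cyclopentyl group on the same carbonyl carbon would separate the two, and a pyrrolidin-2-yl group would show whether a ring nitrogen can stand in for the oxygen.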